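The compounds below may be only part of what the source reports. "The series", "measured", "known", "first", "only" and "open" are said of these compounds alone.

Among the measured compounds shown here, in a functional assay on THP-1 cells (Homo sapiens) for inhibition, read by sulforhodamine B assay, with a stated time of 48 h, tested at 50 uM (on this read-out lower numbers stand for less inhibition of growth and higher numbers for more inhibition of growth at the one concentration tested), compound 1 `COc1ccc(/C=C/C(=O)/C=C/c2ccc(OCc3cn(CCCCCOc4cc(=O)oc5ccccc45)nn3)c(OC)c2)cc1` gives 39%, the lowest of the two numbers measured so far, although compound 2 `COc1ccccc1/C=C/C(=O)/C=C/c1ccc(OCc2cn(CCCCOc3cc(=O)oc4ccccc34)nn2)c(OC)c1` gives 40% and the gap between the two lies within the scatter. Compound 3 `COc1ccccc1/C=C/C(=O)/C=C/c1ccc(OCc2cn(CCCCCOc3cc(=O)oc4ccccc34)nn2)c(OC)c1` has not yet been measured. It differs from compound 1 in one place: 2-methoxyphenyl in place of 4-methoxyphenyl on a double-bonded chain carbon bound to a double-bonded chain carbon. For the measured compounds named here, no measured pair shows this change by itself, so no step can be read for it. Because compound 2 gives 40% while carrying the entering group, the step of a number 1 percentage points higher from compound 1 to compound 3 (within the scatter) is expected to stay within the scatter. Compound 3 is estimated at 40%, within a range of 30% to 50%.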

Compound 3, percent growth inhibition at one concentration: 37%
Estimate against measurement, compound 3: 3 percentage points above, and the stated range covers the measured number.
By their numbers in this assay, from the lowest: compounds 3, 1 and 2 (each within the scatter of the next).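

In this assay, among the compounds shown here, placing 2-methoxyphenyl in place of 4-methoxyphenyl on a double-bonded chain carbon bound to a double-bonded chain carbon gives a number 2 percentage points lower from compound 1 to compound 3 (within the scatter), the first direct reading of this change. At this place, the two methoxyphenyl groups therefore cannot be told apart at the one concentration tested. Nothing available explains this result. Still open, on these data alone, is whether a different group at this place, such as an amine or a carboxylic acid, would shift the number beyond the scatter. Also open, as far as these compounds go, is whether the two methoxyphenyl groups would remain indistinguishable at other concentrations.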